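A few compounds are considered here, and "the series" means these few. Any claim that something is new, unique, unknown or untested is made for them only; others in the source may bear on it.

Compound 1 `CC(=O)N1CCN(c2ccc(Nc3nccc(-c4cn(C)c5ccccc45)n3)cc2)CC1`, in a functional assay on MV4-11 cells (Homo sapiens) for antiproliferative activity, read by resazurin assay, with a stated time of 72 h (on this read-out lower numbers stand for stronger inhibition of growth and higher numbers for weaker inhibition of growth), compound 1 gives 252 nM.
Compound 2 `CC(=O)N1CCN(c2ccc(Nc3nccc(-c4c[nH]c5ncccc45)n3)cc2)CC1`, in this assay compound 2 gives < 1 nM.

The value of compound 2 is a limit of this assay, not a number (the limit of < 1 nM in this assay, at which 1 of the 2 values shown sits). Compound 3 `CC(=O)N1CCN(c2ccc(Nc3nccc(-c4nn(C)c5ccccc45)n3)cc2)CC1` differs from compound 2 in one place: a group of 10 heavy atoms (8 carbon, 2 nitrogen; one five-membered aromatic ring with 2 hetero atoms, one six-membered aromatic ring of carbon only) in place of a group of 9 heavy atoms (7 carbon, 2 nitrogen; one five-membered aromatic ring with 1 hetero atom, one six-membered aromatic ring with 1 hetero atom), on an aromatic carbon. Going by the values given here, the one measured step that bears on this, an at least 250-fold lower number from compound 1 to compound 2 (2.40 log units; beyond the scatter), went the other way, and compound 3 resembles compound 1 in carrying a methylated ring nitrogen and a six-membered ring of carbon only. Compound 3 is therefore expected to give a clearly weaker result than compound 2, an at least 300-fold higher number from compound 2 to compound 3 (2.47 log units; beyond the scatter), with an estimated value near 300 nM (range 60 nM to 1500 nM).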

Compound 3, concentration for 50% growth inhibition: 181 nM
For compound 3 the middle estimate is 1.7-fold (0.22 log units) above the measured one; the measured number falls inside the stated range.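

Replacing 1-methyl-1H-indol-3-yl with 1-methyl-1H-indazol-3-yl at this position gives a 1.4-fold lower number from compound 1 to compound 3 (0.14 log units; within the scatter), so a second nitrogen in the five-membered ring makes no readable difference here. The group of compound 2 stands well apart from this one, with an at least 180-fold higher number from compound 2 to compound 3 (2.25 log units; beyond the scatter). The value of compound 2 is a limit: the limit of < 1 nM in this assay, at which 1 of the 3 values shown sits.

Compound 1 and compound 3 both differ from compound 2 in two features, the methyl group and the six-membered ring of carbon only, and the compounds shown do not separate these. Going by these compounds, it remains open whether an unmethylated 1H-indazol-3-yl group would stand with compound 2 or with compound 3.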